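This account rests on a few compounds, and the source may have more. Where it says the series, first, only, none or still open, it means among the compounds named here.

In a functional assay on HepG2 cells (Homo sapiens) for antiproliferative activity, read by MTT assay (on this read-out higher numbers stand for weaker inhibition and lower numbers for stronger inhibition), compound 1 (`CC1(C)CCc2cc(C(=O)/C=C/c3ccc(OCc4cn(-c5ccc(Cl)cc5)nn4)cc3)c(O)cc2O1`) has no single number, being reported only as "not active" (no number reported) without a figure. Its relative compound 2 (`CC(=O)c1ccc(-n2cc(COc3ccc(/C=C/C(=O)c4ccc5c(c4O)CCC(C)(C)O5)cc3)nn2)cc1`) reads 91400 nM and so inhibits only weakly. Compound 3 (`CC1(C)CCc2cc(C(=O)/C=C/c3ccc(OCc4cn(Cc5ccc([N+](=O)[O-])cc5)nn4)cc3)c(O)cc2O1`) is still unmeasured. Compared with compound 1, it carries 4-nitrobenzyl in place of 4-chlorophenyl on an aromatic nitrogen. Within the data shown here, no measured step shows what this swap does, so in this assay only a small move is expected, from no activity towards weak activity. Compound 3 is expected at an estimated 80000 nM with a likely range from 30000 nM to 200000 nM around that value.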

Compound 3, half-maximal inhibitory concentration: 109000 nM
For compound 3 the middle estimate is 1.4-fold (0.13 log units) below the measured one; low and high end bracket the measured number.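

Compound 1 has no number, so the change from it to compound 3 cannot be read as a step. On these data alone, what swapping 4-chlorophenyl for 4-nitrobenzyl does to activity stays open. No supporting evidence bears on this result.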